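Cinnamamide series on a shared quinazoline-free core: aryl variation

The source may report more compounds than this note shows. Statements on the series, on what has been measured and on what is new or still open speak of the compounds shown alone.

Measured compounds:
compound 1 `COc1cc(/C=C/C(=O)Nc2cc3c(Nc4ccc(F)c(Cl)c4)ncnc3cc2O[C@H]2CCOC2)cc(OC)c1O` — 27400 nM
compound 2 `O=C(/C=C/c1cc(Br)c(O)c(Br)c1)Nc1cc2c(Nc3ccc(F)c(Cl)c3)ncnc2cc1O[C@H]1CCOC1` — 27700 nM
compound 3 `COc1ccc(/C=C/C(=O)Nc2cc3c(Nc4ccc(F)c(Cl)c4)ncnc3cc2OC)cc1` — "not determined" (no result reported)

The series shares one core and varies the aryl group on the double-bonded chain carbon bound to a double-bonded chain carbon. In a functional assay on HeLa cells (Homo sapiens) for cytotoxicity, read by MTT assay, with a stated time of 72 h (a higher number here means a weaker inhibitor, a lower number a stronger inhibitor), compound 1 gives 27400 nM, the lowest of the two numbers recorded, with compound 2 as its nearest neighbour at 27700 nM. The step of a 1.0-fold higher number from compound 1 to compound 2 (0.00 log units; within the scatter) is within the scatter, so the two cannot be ordered. For compound 3 no number is available in this assay.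

Compound 4 `COc1ccc(/C=C/C(=O)Nc2cc3c(Nc4ccc(F)c(Cl)c4)ncnc3cc2O[C@H]2CCOC2)cc1` is not yet measured. It differs from compound 1 as follows: 4-methoxyphenyl in place of 4-hydroxy-3,5-dimethoxyphenyl on a double-bonded chain carbon bound to a double-bonded chain carbon. Going by the values given here, the only step that bears on this change is the aryl swap from compound 1 to compound 2, which left the number essentially unchanged (a 1.0-fold higher number from compound 1 to compound 2 (0.00 log units; within the scatter)). That step involved a different aryl group than the one entering here, so it is an indirect guide only; still, nothing measured suggests that an aryl change at this position moves the number beyond the scatter.

The expectation for compound 4 is therefore a step of about a 1.1-fold higher number from compound 1 to compound 4 (0.04 log units; within the scatter) in this assay, with no direction beyond the scatter. Compound 4 is estimated at 30000 nM, with a range of 12000 nM to 75000 nM.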

Compound 4, half-maximal inhibitory concentration: 34600 nM
The estimate for compound 4 lay 1.2-fold (0.06 log units) below the measured number; low and high end bracket the measured number.
By their numbers in this assay, from the lowest: compounds 1, 2 and 4 (each within the scatter of the next).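

In this assay, going by these compounds alone, the aryl group on the double-bonded chain carbon bound to a double-bonded chain carbon was changed for the first time in a way that removes the hydroxyl group, and the outcome is a 1.3-fold higher number from compound 1 to compound 4 (0.10 log units; within the scatter). The 4-methoxyphenyl group has 0 hydrogen-bond donors and 8 heavy atoms, against 1 hydrogen-bond donor and more heavy atoms in 4-hydroxy-3,5-dimethoxyphenyl, so on the shared core neither the hydrogen-bond donor nor the size of the group separates these two compounds. The comparison with the halogenated aryl group gives the same reading, with a 1.2-fold higher number from compound 2 to compound 4 (0.10 log units; within the scatter), so the three aryl groups shown cannot be ordered at this position, and nothing on hand offers an explanation for this flat result.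

Going by these compounds, whether a dimethylamino group or a carboxylic acid on the aryl ring, or a longer chain in place of the aryl group, would give a step beyond the scatter remains open. On these data alone, compound 3 has no number in this assay, so the group on the core that sets it apart from compound 4 also remains open.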